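Amide nitrogen substituent: chlorophenyl to chloropyridyl

This account rests on a few compounds, and the source may have more. Where it says the series, first, only, none or still open, it means among the compounds named here.

Three amides on a shared core have been measured in a functional assay on HeLa cells (Homo sapiens) for inhibition, read by MTT assay, with a stated time of 72 h; a lower number here means a stronger inhibitor, a higher number a weaker inhibitor. Compound 1 `CCCNC(=O)c1ccc(Oc2nc(-c3c(C)noc3C)cnc2N)cc1` gives 32100 nM, compound 2 `Cc1noc(C)c1-c1cnc(N)c(Oc2ccc(C(=O)NC3CCCC3)cc2)n1` gives 9970 nM, and compound 3 `Cc1noc(C)c1-c1cnc(N)c(Oc2ccc(C(=O)Nc3ccccc3Cl)cc2)n1` gives 81300 nM. Compound 3 thus stands at the highest number of the three: a 2.5-fold higher number from compound 1 to compound 3 (0.40 log units; beyond the scatter) and an 8.2-fold higher number from compound 2 to compound 3 (0.91 log units; beyond the scatter), while the two alkyl amides are separated by a 3.2-fold lower number from compound 1 to compound 2 (0.51 log units; beyond the scatter).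

Compound 4 `Cc1noc(C)c1-c1cnc(N)c(Oc2ccc(C(=O)Nc3ccc(Cl)cn3)cc2)n1` differs from compound 3 by 5-chloropyridin-2-yl in place of 2-chlorophenyl on an amide-type nitrogen. Within the data shown here, none of the measured steps exchanges one aromatic group on the amide nitrogen for another; the two steps ending at compound 3 only show that an aromatic group there gave a higher number than propyl or cyclopentyl. The present change keeps an aromatic ring of the same size, so no step beyond the scatter in this assay is expected, and the estimate for compound 4 is placed close to compound 3, at 60000 nM with a range of 15000 nM to 250000 nM, which corresponds to an expected step of a 1.4-fold lower number from compound 3 to compound 4 (0.13 log units; within the scatter).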

Compound 4, half-maximal inhibitory concentration: 19200 nM
Beside the measured number, compound 4's estimate is 3.1-fold (0.49 log units) above it, and the stated range covers the measured number.
By their numbers in this assay, from the lowest: compounds 2, 4 and 1 (each within the scatter of the next, the first and the last beyond it); then compound 3.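

In this assay the exchange of one aromatic group on the amide-type nitrogen for another is itself a step beyond the scatter, with a 4.2-fold lower number from compound 3 to compound 4 (0.63 log units; beyond the scatter) for 5-chloropyridin-2-yl in place of 2-chlorophenyl. An aromatic group at this position therefore does not of itself carry the higher number: a 1.9-fold higher number from compound 2 to compound 4 (0.28 log units; within the scatter) and a 1.7-fold lower number from compound 1 to compound 4 (0.22 log units; within the scatter) both lie within the scatter. Nothing at hand bears on the reason for this step.

The change alters the ring nitrogen and the place of the chlorine together, and the compounds shown do not separate the two; 4-chlorophenyl or unsubstituted pyridin-2-yl on the amide-type nitrogen would. Also open, from the compounds shown here alone, is how a benzyl group or a longer alkyl chain at this position would read in this assay against these four amides.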